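From Ethyl to Tert-Butyl in One Step

The source may hold more compounds than are shown below. What is called first, only, known or untested is meant among the compounds shown, and "the series" means these compounds.

Of the compounds shown here, three have been measured in a functional assay on the whole organism (6C3HED cells, Mus musculus) for inhibition, at a dose of 150 mg/kg by the oral route; on this read-out higher numbers stand for more inhibition at the one dose given (going by the name of the read-out) and lower numbers for less inhibition. Compound 1 `Cc1ccc(S(=O)(=O)NC(=O)Nc2ccc(Cl)c(Cl)c2)s1` gives 24%. Compound 2 `CSc1ccc(S(=O)(=O)NC(=O)Nc2ccc(Cl)cc2)s1` gives 29%. Compound 3 `CCc1ccc(S(=O)(=O)NC(=O)Nc2ccc(Cl)cc2)s1` gives 57%, the highest of the three numbers; the nearest is compound 2 and the furthest compound 1, and both gaps lie beyond the scatter. Among the compounds with values here, the one step between measured compounds that differ in a single place, a number 28 percentage points higher from compound 2 to compound 3 (beyond the scatter), put ethyl in place of methylsulfanyl on an aromatic carbon. Compound 4 `CC(C)(C)c1ccc(S(=O)(=O)NC(=O)Nc2ccc(Cl)cc2)s1` takes the next step from compound 3: tert-butyl in place of ethyl on an aromatic carbon. Within the data shown here, no measured step exchanges ethyl for tert-butyl, so the step from compound 2 to compound 3 is only a loose guide, and it shows that one change at this position moved the number by a modest amount. The expected step, a number 7 percentage points lower from compound 3 to compound 4 (within the scatter), is therefore small and within the scatter, and compound 4 is estimated at 50%, with a range from 25% to 75% in this assay.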

Compound 4, a percentage reported as inhibition, in the whole organism at one dose (the size of the read-out at that dose, not a potency): 7%
Compound 4: middle estimate off by 43 percentage points, on the high side; the measured number lies below the stated range.
By their numbers in this assay, from the lowest: compound 4; then compounds 1 and 2 (each within the scatter of the next); then compound 3.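

Going from ethyl to tert-butyl at this place on the ring, next to the ring sulfur, gives a number 50 percentage points lower from compound 3 to compound 4 (beyond the scatter) in this assay and shows that the read-out is highly sensitive to which carbon group sits there. Within the data shown here, this is a larger move than the only earlier step at this position, a number 28 percentage points higher from compound 2 to compound 3 (beyond the scatter) and it runs the other way. Tert-butyl also falls short of methylsulfanyl, with a number 22 percentage points lower from compound 2 to compound 4 (beyond the scatter) so the gain seen with ethyl does not carry over to the larger carbon group.

Still open, from the compounds shown here alone, is how the number behaves with propyl or isopropyl at this place, which could show whether the fall sets in gradually or abruptly. Nothing measured here gives a reason for the fall.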